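A few compounds are considered here, and "the series" means these few. Any claim that something is new, unique, unknown or untested is made for them only; others in the source may bear on it.

The set comprises three measured compounds and one that awaits measurement, all sharing a core decorated with a hydroxymethyl-bearing cyclopentane diol on an amino group. Among the compounds with values here, compound 1 `Nc1nc(Cl)c(-c2nc3ccccc3o2)c(N[C@@H]2C[C@H](CO)[C@@H](O)[C@H]2O)n1` and compound 2 `COc1ccc2nc(-c3c(Cl)nc(N)nc3N[C@@H]3C[C@H](CO)[C@@H](O)[C@H]3O)sc2c1` differ from compound 3 `Cc1nc(NCC2CC2)nc(N[C@@H]2C[C@H](CO)[C@@H](O)[C@H]2O)c1-c1nc2ccccc2s1` in several places at once, so no single step among them can be read. In an ADME assay on cells (Homo sapiens) for cytotoxicity, read by polymerase chain reaction, with a stated time of 3 days (on this read-out lower numbers stand for higher toxicity in this test and higher numbers for lower toxicity in this test), compound 1 gives 12000 nM. Compound 2 reaches only a limit of this assay, > 25000 nM, which is the ceiling described as the limit of > 25000 nM in this assay, at which 1 of the 3 values shown sits. Compound 3 gives 8000 nM, the lowest of the two real numbers, though its nearest neighbour, compound 1, sits within the usual scatter of it, so the two cannot be ordered.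

Compound 4 `Cc1nc(NCc2ccsc2)nc(N[C@@H]2C[C@H](CO)[C@@H](O)[C@H]2O)c1-c1nc2ccccc2s1` is compound 3 with one change: thiophen-3-yl in place of cyclopropyl on a saturated chain carbon bound to a nitrogen on an aromatic ring. Within the data shown here, no measured pair in this set isolates such a swap, so the expected size of the step rests on the spread already seen, which is narrow. The step from compound 3 to compound 4 in this assay is expected to be small, a 1.1-fold lower number from compound 3 to compound 4 (0.06 log units; within the scatter), not clearly beyond the scatter in either direction. Compound 4 is therefore estimated at 7000 nM, with a likely range from 3000 nM to 18000 nM.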

Compound 4, half-maximal cytotoxic concentration: 6000 nM
Beside the measured number, compound 4's estimate is 1.2-fold (0.07 log units) above it; the range from low to high includes it.
By their numbers in this assay, from the lowest: compounds 4, 3 and 1 (each within the scatter of the next). At a limit, above all of these: compound 2.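

In this assay, within the data shown here, the swap of cyclopropyl for thiophen-3-yl on a saturated chain carbon bound to a nitrogen on an aromatic ring gives the first step in this set that can be read, a 1.3-fold lower number from compound 3 to compound 4 (0.12 log units; within the scatter). It shows that this position accepts a five-membered aromatic ring with a sulfur atom in place of a three-membered carbon ring with no difference that can be told from the scatter, even though the entering group has 5 heavy atoms against 3 and brings 1 hydrogen-bond acceptor where cyclopropyl has none. Nothing given here bears on why the two compounds read alike, and a single step within the scatter shows no trend at this position.

As far as these compounds go, it remains open whether a basic amine, a carboxylic acid or a longer chain in this place would give a step beyond the scatter, since both groups compared here are small rings on the same chain carbon. Compound 1 and compound 2 differ from these two in several places at once, so the steps to them cannot be read and the contribution of the other places on the shared core stays unresolved.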